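Adenosine receptor antagonists: aryl variation at the shared core

The source may report more compounds than this note shows. Statements on the series, on what has been measured and on what is new or still open speak of the compounds shown alone.

Measured so far in a functional assay on CHO-K1 cells for antagonist activity at adenosine receptor A1 (Homo sapiens), read by a beta-galactosidase reporter and cAMP accumulation, with stated times of 15 min and 6 h; on this read-out higher numbers stand for weaker inhibition and lower numbers for stronger inhibition:
- compound 1 `Nc1nc(C2CCCO2)nc2sc(Cc3ccccc3)cc12` gives 2950 nM
- compound 2 `Nc1nc(-c2ccccc2)nc2sc(Cc3ccccc3)cc12` gives 151 nM
- compound 3 `Nc1nc(-c2ccccn2)nc2sc(Cc3ccccc3)cc12` gives 3710 nM

Compound 3 carries the highest number of the three. Its nearest neighbour is compound 1, and a 1.3-fold higher number from compound 1 to compound 3 (0.10 log units; within the scatter) stays within the scatter, so the two are not distinguished. Against compound 2 the gap is wide: a 25-fold higher number from compound 2 to compound 3 (1.39 log units; beyond the scatter), a large step, the mirror of a 20-fold lower number from compound 1 to compound 2 (1.29 log units; beyond the scatter), which marks phenyl as the group that sets compound 2 apart.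

Compound 4 `Nc1nc(-c2cccc(Cl)n2)nc2sc(Cc3ccccc3)cc12` keeps the pyridin-2-yl of compound 3 and adds a single substituent: chloro in place of hydrogen on an aromatic carbon, on the aromatic carbon next to the ring nitrogen, meta to a large group, so that pyridin-2-yl becomes 6-chloropyridin-2-yl.

For the measured compounds named here, none of the measured steps concerns a chloro substituent or any change on the pyridin-2-yl ring itself; the three steps all exchange the whole group on the aromatic carbon. They therefore do not bear directly on this change and give no direction. For compound 4 the expectation is a step of a 1.2-fold lower number from compound 3 to compound 4 (0.09 log units; within the scatter) in this assay, that is, nothing clearly beyond the scatter, with the range kept wide to cover either direction. Compound 4 is thus estimated at 3000 nM, between 700 nM and 12000 nM.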

Compound 4, inhibition constant: > 1000 nM
Compound 4: only a limit was reported (the forecaster's own chance of this, stated with the estimate: 10%); the middle value is on the limit's open side.
By their numbers in this assay, from the lowest: compound 2; then compounds 1 and 3 (each within the scatter of the next).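

In this assay compound 4 is reported only as a limit, > 1000 nM. For the compounds shown here, the steps to compound 4 from compound 3 and from compound 1 cannot be read, because the only value for compound 4 is that limit: the limit of > 1000 nM in this assay, at which 1 of the 4 values shown sits. The one readable step is an at least 6.6-fold higher number from compound 2 to compound 4 (0.82 log units; beyond the scatter), with 6-chloropyridin-2-yl in place of phenyl, so chloro on the aromatic carbon next to the ring nitrogen does not bring the pyridine series back to the level of the phenyl compound, and the gap that separated pyridin-2-yl from phenyl is not closed by this single added atom.

Going by these compounds, whether chloro in place of hydrogen moves the number at all relative to pyridin-2-yl remains open, and so does the direction of any such move, since the limit does not separate compound 4 from compound 3. Also open, on these data alone, is how this same place on the ring responds to groups other than chloro, such as methyl, methoxy or an amine, and whether chloro on the phenyl ring of compound 2 would give a comparable step.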